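Oxazolylcarbonyl replacing methylsulfonyl on the ring nitrogen

The source may report more compounds than this note shows. Statements on the series, on what has been measured and on what is new or still open speak of the compounds shown alone.

Compound 1 `CCCCNc1nc(N)nc2c1CCN(C)C2` and compound 2 `CCCCNc1nc(N)nc2c1CN(S(C)(=O)=O)CC2` share a core and are measured in an assay on HEK293 cells for agonist activity at Toll-like receptor 8 (Homo sapiens), read by a luciferase reporter, with a stated time of 6 h; a higher number here means that more compound is needed for the effect, a lower number that less compound is needed. Compound 1 gives 0.2 uM in this assay. Compound 2 gives 9.9 uM, the higher of the two numbers, with compound 1 lower by a margin beyond the scatter. Compound 3 `CCCCNc1nc(N)nc2c1CN(C(=O)c1cocn1)CC2` is not yet measured; it differs from compound 2 by (1,3-oxazol-4-yl)carbonyl in place of methylsulfonyl on an amine nitrogen in a ring. For the measured compounds named here, no measured step covers this change, so the expected size of a 3.3-fold lower number from compound 2 to compound 3 (0.52 log units; beyond the scatter) is a modest move toward a lower number, within wide bounds. Compound 3 is expected to give about 3 uM, estimated between 0.5 uM and 20 uM.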

Compound 3, minimum effective concentration: 0.2 uM
Compound 3: middle estimate off by 15-fold (1.18 log units), on the high side; the whole stated range lies above it.
By their numbers in this assay, from the lowest: compounds 1 and 3 (each within the scatter of the next); then compound 2.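

In this assay, the group on this amine nitrogen in a ring strongly shifts the number: (1,3-oxazol-4-yl)carbonyl in place of methylsulfonyl gives a 50-fold lower number from compound 2 to compound 3 (1.69 log units; beyond the scatter). The position therefore accepts a five-membered aromatic ring carried on a carbonyl, a change much larger than a small substituent swap might suggest. Nothing shown gives a reason for this step. Still open, on these data alone, is whether the shift belongs to the carbonyl or to the oxazole ring. An acetyl or a benzoyl on the same nitrogen would separate the two.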